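This account rests on a few compounds, and the source may have more. Where it says the series, first, only, none or still open, it means among the compounds named here.

- Compound 1 `CCCCNc1nc(N)nc2cccc(C)c12` gives > 25000 nM, a limit
- Compound 2 `CCCCNc1nc(N)nc2cccc(CCc3ccccc3)c12` gives > 25000 nM, a limit

In an ADME assay on HEK293 cells (Homo sapiens) for cytotoxicity, with a stated time of 6 h (on this read-out higher numbers stand for lower toxicity in this test and lower numbers for higher toxicity in this test), compound 2 has no exact value, only the limit > 25000 nM. Both measured compounds sit at the same limit, as the limit of > 25000 nM in this assay, at which 2 of the 2 values shown sit, shows. Compound 3 `CCCCNc1nc(N)nc2cccc(OCc3ccccc3)c12` carries benzyloxy in place of phenethyl on an aromatic carbon, (benzyloxy in place of phenethyl on an aromatic carbon). Among the compounds with values here, the only measured step, a step that the two limits leave unreadable from compound 1 to compound 2, has no readable size, so it offers no size or direction to carry over. No change beyond the usual scatter is therefore expected, and the estimated step is a number no higher from compound 2 to compound 3 (the limit leaves the size open). Compound 3 is expected near 25000 nM, within an estimated range of 12000 nM to 40000 nM.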

Compound 3, half-maximal cytotoxic concentration: 10000 nM
Compound 3: middle estimate off by 2.5-fold (0.40 log units), on the high side; measured number below the stated range.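

In this assay, this aromatic carbon now shows a readable effect of its substituent: benzyloxy in place of phenethyl gives an at least 2.5-fold lower number from compound 2 to compound 3 (0.39 log units; beyond the scatter), and benzyloxy in place of methyl gives an at least 2.5-fold lower number from compound 1 to compound 3 (0.39 log units; beyond the scatter). Phenethyl and benzyloxy each have 8 heavy atoms, yet the lower number appears with the group that carries oxygen. Both steps give only a minimum size because compound 1 and compound 2 sit at a limit: the limit of > 25000 nM in this assay, at which 2 of the 3 values shown sit.

From the compounds shown here alone, the full size of both steps stays open. So does whether an amine in place of the oxygen, or a longer chain between oxygen and phenyl ring, would give the same result.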